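Thioester series: propanoyl to acetyl

This account rests on a few compounds, and the source may have more. Where it says the series, first, only, none or still open, it means among the compounds named here.

In a functional assay on PC-3 cells (Homo sapiens) for inhibition, read by MTT assay, with a stated time of 96 h (a higher number here means a weaker inhibitor of growth, a lower number a stronger inhibitor of growth), compound 1 `O=C(OCc1ccccc1)SCCCCCCNC(=O)c1cc(-c2ccncc2)n[nH]1` gives 15400 nM and compound 2 `CC(C)C(=O)SCCCCCCNC(=O)c1cc(-c2ccncc2)n[nH]1` gives 22400 nM. Between them lies a 1.5-fold higher number from compound 1 to compound 2 (0.16 log units; within the scatter).

Compound 3 `CCC(=O)SCCCCCCNC(=O)c1cc(-c2ccncc2)n[nH]1` reads > 50000 nM in this assay, which is a limit and not a number. Compound 3 therefore stands at the limit of > 50000 nM in this assay, at which 1 of the 3 values shown sits.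

Compound 4 `CC(=O)SCCCCCCNC(=O)c1cc(-c2ccncc2)n[nH]1` differs from compound 3 by hydrogen in place of methyl on a saturated chain carbon bound to a carbonyl carbon, or propanoyl to acetyl.

Among the compounds with values here, the closest precedent is the same replacement in compound 2, which gave an at least 2.2-fold higher number from compound 2 to compound 3 (0.34 log units; beyond the scatter). Compound 1 adds an at least 3.2-fold higher number from compound 1 to compound 3 (0.51 log units; beyond the scatter). Going by these compounds, both steps are bounded on one side only, so their true sizes are unknown. A small further move toward the weaker end of this assay is expected, with no gain in growth inhibition.

The expected step is a step that the limit leaves unreadable from compound 3 to compound 4. For compound 4 the estimated value is 60000 nM, with an expected range of 25000 nM to 120000 nM.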

Compound 4, concentration for 50% growth inhibition: 36000 nM
Beside the measured number, compound 4's estimate is 1.7-fold (0.22 log units) above it; the measured number falls inside the stated range.
By their numbers in this assay, from the lowest: compounds 1, 2 and 4 (each within the scatter of the next, the first and the last beyond it). At a limit, above all of these: compound 3.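

In this assay, within the data shown here, going from propanoyl to acetyl gives an at least 1.3-fold lower number from compound 3 to compound 4 (0.14 log units; that floor lies within the scatter) and so does not continue the upward direction of the earlier steps to compound 3, but that floor leaves the reversal unproven. Methyl and isopropyl on the carbonyl carbon are not told apart, with a 1.6-fold higher number from compound 2 to compound 4 (0.21 log units; within the scatter) as the printed step, whereas methyl in place of benzyloxy gives a 2.3-fold higher number from compound 1 to compound 4 (0.37 log units; beyond the scatter) and so extends the gap from benzyloxy beyond compound 3 to a compound with a real number. Compound 3 remains a limit and not a number, so no trend in acyl size can be read through it: the limit of > 50000 nM in this assay, at which 1 of the 4 values shown sits.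

Still open, going by these compounds, is the true position of compound 3 relative to compound 4. Also open, on these data alone, is how a butanoyl group, a free thiol or a longer chain in place of the hexyl linker would read.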